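Replacing the tetramethylpiperidinyl group: an expected loss

The source may report more compounds than this note shows. Statements on the series, on what has been measured and on what is new or still open speak of the compounds shown alone.

In an assay on HEK293 cells for displacement of a labelled ligand from NPC1-like intracellular cholesterol transporter 1 (Homo sapiens) (on this read-out higher numbers stand for weaker inhibition and lower numbers for stronger inhibition), three compounds have been measured. Compound 1 `CC1(C)CC(OC(=O)CN2CN(c3ccccc3)C3(CCN(C(=O)c4ccc(C5CCCCC5)cc4)CC3)C2=O)CC(C)(C)N1` gives 600 nM. Compound 2 `CC1(C)CC(OC(=O)CN2CN(c3ccccc3)C3(CCN(C(=O)c4ccc(C(C)(C)C)cc4)CC3)C2=O)CC(C)(C)N1` gives 1300 nM. Compound 3 `CC(C)(C)c1ccc(C(=O)N2CCC3(CC2)C(=O)N(CC(=O)NCCCCN)CN3c2ccccc2)cc1` gives 14500 nM.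

Compound 1 has the lowest number of the three: there is a 2.2-fold higher number from compound 1 to compound 2 (0.34 log units; beyond the scatter), and compound 3 with 14500 nM lies far higher still.

Compound 4 `NCCNC(=O)CN1CN(c2ccccc2)C2(CCN(C(=O)c3ccc(C4CCCCC4)cc3)CC2)C1=O` differs from compound 1 in one place: (2-aminoethyl)amino in place of (2,2,6,6-tetramethylpiperidin-4-yl)oxy on a carbonyl carbon. Going by the values given here, the one measured step that bears on this is an 11-fold higher number from compound 2 to compound 3 (1.05 log units; beyond the scatter), where the same group left and (4-aminobutyl)amino entered. A change of the same kind is therefore expected to raise the number for compound 4 by a large step, well beyond the scatter. Compound 4 is estimated to give 6000 nM, with a range from 2000 nM to 20000 nM, an expected 10-fold higher number from compound 1 to compound 4 (1.00 log units; beyond the scatter).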

Compound 4, half-maximal inhibitory concentration: 3800 nM
For compound 4 the middle estimate is 1.6-fold (0.20 log units) above the measured one; the range from low to high includes it.
By their numbers in this assay, from the lowest: compound 1; then compound 2; then compound 4; then compound 3.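

In this assay the loss on leaving (2,2,6,6-tetramethylpiperidin-4-yl)oxy now appears with both aromatic substituents, with a 6.3-fold higher number from compound 1 to compound 4 (0.80 log units; beyond the scatter) on the cyclohexyl side and an 11-fold higher number from compound 2 to compound 3 (1.05 log units; beyond the scatter) on the tert-butyl side. The two steps also bring in different chains, (2-aminoethyl)amino and (4-aminobutyl)amino, and therefore do not show what chain length alone does. Nothing available explains this rise.

Still open, as far as these compounds go, is whether the oxygen link or the ring matters more: a (2,2,6,6-tetramethylpiperidin-4-yl)amino group on the same carbonyl carbon would separate the two.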